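A few compounds are considered here, and "the series" means these few. Any claim that something is new, unique, unknown or untested is made for them only; others in the source may bear on it.

Measured compounds in an ADME assay on MT4 cells (Homo sapiens) for cytotoxicity, read by MTT assay; a higher number here means that more compound is tolerated, a lower number that less compound is tolerated:
- compound 1 `O=C1c2ccccc2C(=O)N1CCOC(=S)N(C(=O)c1ccc(C(F)(F)F)cc1)c1ccc(Cl)cc1` gives 10000 nM
- compound 2 `Cc1ccc(N(C(=O)c2ccccc2[N+](=O)[O-])C(=S)OCCN2C(=O)c3ccccc3C2=O)cc1` gives 100000 nM
- compound 3 `O=C1c2ccccc2C(=O)N1CCOC(=S)N(C(=O)c1ccc(Cl)c([N+](=O)[O-])c1)c1ccccc1` gives 51000 nM

Compound 1 stands at the lowest number of the three in this assay: compound 3 sits above it by a gap beyond the usual scatter, and compound 2 sits further above it by a gap that is also beyond the scatter. Compound 1 is therefore the least tolerated of the three measured compounds.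

Compound 4 `O=C1c2ccccc2C(=O)N1CCOC(=S)N(C(=O)c1ccc([N+](=O)[O-])cc1Cl)c1ccc(Cl)cc1` has not yet been measured in this assay. It differs from compound 1 in one place: 2-chloro-4-nitrophenyl in place of 4-(trifluoromethyl)phenyl on a carbonyl carbon. The shared core and the 4-chlorophenyl on the amide-type nitrogen are unchanged.

Going by the values given here, no step between two measured compounds that differ in a single place is available, so the size of the step from compound 1 to compound 4 cannot be read directly from the data. Compound 2 and compound 3 both carry a nitrophenyl on the carbonyl carbon and both give higher numbers than compound 1, so an upward step is expected, but beyond this the picture is thin. A modest rise is estimated: from compound 1 to compound 4 the expected step is a 3.0-fold higher number from compound 1 to compound 4 (0.48 log units; beyond the scatter), with compound 4 expected at 30000 nM, within a range from 10000 nM to 100000 nM.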

Compound 4, half-maximal cytotoxic concentration: 19000 nM
The estimate for compound 4 lay 1.6-fold (0.20 log units) above the measured number; the measured number falls inside the stated range.
By their numbers in this assay, from the lowest: compounds 1 and 4 (each within the scatter of the next); then compounds 3 and 2 (each within the scatter of the next).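

In this assay, going by these compounds alone, putting 2-chloro-4-nitrophenyl in place of 4-(trifluoromethyl)phenyl on a carbonyl carbon gives a 1.9-fold higher number from compound 1 to compound 4 (0.28 log units; within the scatter) and this is the first step in which only one place differs. The earlier compounds shown here differed from each other in more than one place and could not show what this position does alone; here, with the shared core and the 4-chlorophenyl on the amide-type nitrogen unchanged, a group with hydrogen-bond acceptors and a group without any are not told apart by the assay. Nothing available offers a measured reason for this outcome.

This single exchange says nothing about how a carboxylic acid, an amine or a longer chain would read in place of the substituted phenyl on the carbonyl carbon. As far as these compounds go, it also remains open whether the same exchange would read the same way with a pyridine ring or a plain alkyl chain on the amide-type nitrogen, where the 4-chlorophenyl now stands.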